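Working notes: the substituent on the carbonyl carbon

The source may hold more compounds than are shown below. What is called first, only, known or untested is meant among the compounds shown, and "the series" means these compounds.

Measured so far in a functional assay on isolated protein for inhibition of Glucose-dependent insulinotropic receptor (Rattus norvegicus), read by HTRF and cAMP accumulation; on this read-out higher numbers stand for an effect only at larger amounts of compound and lower numbers for an effect already at smaller amounts:
compound 1 `Cc1nc(S(C)(=O)=O)ccc1Oc1ncnc(OC2CCN(C(=O)O[C@H](C)CF)CC2)c1F` gives 1520 nM
compound 2 `CCC1(OC(=O)N2CCC(Oc3ncnc(Oc4ccc(S(C)(=O)=O)nc4C)c3F)CC2)CC1` gives 333 nM
compound 3 `Cc1nc(S(C)(=O)=O)ccc1Oc1ncnc(OC2CCN(C(=O)SC3CCC3)CC2)c1F` gives 77.4 nM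

Compound 3 stands lowest of the three numbers; compound 2 is nearest to it and compound 1 furthest. The three compounds differ only in the group on the carbonyl carbon, and every step lies beyond the scatter: a 4.6-fold lower number from compound 1 to compound 2 (0.66 log units; beyond the scatter), a 20-fold lower number from compound 1 to compound 3 (1.29 log units; beyond the scatter), a 4.3-fold lower number from compound 2 to compound 3 (0.63 log units; beyond the scatter).

Compound 4 `Cc1nc(S(C)(=O)=O)ccc1Oc1ncnc(OC2CCN(C(=O)c3noc(C(C)C)n3)CC2)c1F` is not yet measured. It differs from compound 3 in one place: 5-isopropyl-1,2,4-oxadiazol-3-yl in place of cyclobutylsulfanyl on a carbonyl carbon.

All three measured steps bear on this same position and range from modest to large, so a change beyond the scatter in this assay is the working expectation. Among the compounds with values here, no measured compound carries an aromatic ring, or a ring with hetero atoms, on this carbonyl carbon, so the direction cannot be read from the pairs. A move upward is judged somewhat more likely than a further fall because a 20-fold lower number from compound 1 to compound 3 (1.29 log units; beyond the scatter) and a 4.3-fold lower number from compound 2 to compound 3 (0.63 log units; beyond the scatter) both end at compound 3 from above, leaving less room below.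

Compound 4 is expected at 150 nM, in the range 40 nM to 600 nM. This estimate means an expected step of a 1.9-fold higher number from compound 3 to compound 4 (0.29 log units; within the scatter).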

Compound 4, half-maximal effective concentration: 176 nM
Compound 4: the middle estimate sits 1.2-fold (0.07 log units) below what was measured; the range from low to high includes it.
By their numbers in this assay, from the lowest: compound 3; then compounds 4 and 2 (each within the scatter of the next); then compound 1.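

In this assay the carbonyl carbon turns out to accept a ring carbon of an aromatic ring with 3 hetero atoms, so neither sulfur nor oxygen is needed on it for a number in this range: placing 5-isopropyl-1,2,4-oxadiazol-3-yl there in place of cyclobutylsulfanyl gives a 2.3-fold higher number from compound 3 to compound 4 (0.36 log units; beyond the scatter) and costs only a modest step. Against the 1-ethylcyclopropyl group on oxygen the same ring gives a 1.9-fold lower number from compound 2 to compound 4 (0.28 log units; within the scatter) and no order can be drawn between those two, while against the 1-(fluoromethyl)ethyl group on oxygen it gives an 8.6-fold lower number from compound 1 to compound 4 (0.94 log units; beyond the scatter) and stays clearly on the lower side. No independent measurement is available to explain any of these steps.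

The compounds shown do not separate the contribution of the ring from that of its isopropyl group, so an oxadiazole bearing methyl or tert-butyl in place of isopropyl would be the informative comparison. On these data alone, it also remains open how a phenyl ring, a pyridine ring or a cyclobutylamine on the carbonyl carbon would stand against the cyclobutylsulfanyl group of compound 3.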